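A few compounds are considered here, and "the series" means these few. Any claim that something is new, unique, unknown or untested is made for them only; others in the source may bear on it.

Compound 1 `COc1cc(/C=C/C(=O)c2sc(Nc3ccc(C)cc3)nc2C)cc(OC)c1OC` carries a 4-methylphenyl on a nitrogen on an aromatic ring. In a functional assay on BGC-823 cells (Homo sapiens) for cytotoxicity, read by MTT assay (on this read-out higher numbers stand for weaker inhibition and lower numbers for stronger inhibition), compound 1 gives only a limit, > 25000 nM. Compound 2 `COc1cc(/C=C/C(=O)c2sc(Nc3ccccc3C)nc2C)cc(OC)c1OC` differs from compound 1 in one place: 2-methylphenyl in place of 4-methylphenyl on a nitrogen on an aromatic ring. In this assay compound 2 gives 5400 nM. This single swap produced an at least 4.6-fold lower number from compound 1 to compound 2 (0.66 log units; beyond the scatter), and because the values cluster at the limit of > 25000 nM in this assay, at which 2 of the 3 values shown sit, the true size of that step may be larger than the measurement can show.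

Compound 3 `Cc1ccc(Nc2nc(C)c(C(=O)/C=C/c3ccccc3Cl)s2)cc1` shares the (4-methylphenyl)amino group of compound 1 but is built on a different core; the difference between the two cores is not broken down here. In this assay compound 3 gives only a limit, > 25000 nM. Compound 4 `Cc1ccccc1Nc1nc(C)c(C(=O)/C=C/c2ccccc2Cl)s1` has not yet been measured. It stands to compound 3 as compound 2 stands to compound 1: 2-methylphenyl in place of 4-methylphenyl on a nitrogen on an aromatic ring. The place of the change reads the same in both pairs, so it is the same change, not merely the same kind.

Because the same change gave an at least 4.6-fold lower number from compound 1 to compound 2 (0.66 log units; beyond the scatter), a step of similar size is expected here: an at least 2.7-fold lower number from compound 3 to compound 4 (0.44 log units; beyond the scatter). Compound 4 is accordingly estimated at 9000 nM in this assay. Compound 4 is expected to fall between 2500 nM and 25000 nM, and with compound 3 known only as a limit, compound 4 may itself remain at a limit.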

Compound 4, half-maximal inhibitory concentration: > 25000 nM
Compound 4 gave a limit, no number; the forecaster's own chance of this, stated with the estimate: 35%; middle value at least 2.7-fold (0.44 log units) from the limit.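

No step can be read from compound 3 to compound 4, because in this assay both compounds stop at a limit instead of giving a number: the limit of > 25000 nM in this assay, at which 3 of the 4 values shown sit.

Still open, on these data alone, is whether 2-methylphenyl in place of 4-methylphenyl changes the read-out at all on the core of compound 3, as it did on the core of compound 1, or whether any such change stays hidden behind that limit.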